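Chloro in place of hydrogen, repeated on a second core

The source may hold more compounds than are shown below. What is called first, only, known or untested is meant among the compounds shown, and "the series" means these compounds.

Compound 2 `Clc1ccc(C(c2c[nH]cc2-c2ccc(Cl)cc2-c2ccccc2)n2ccnc2)cc1` and compound 1 `Clc1ccc(C(c2c[nH]cc2-c2ccc(Cl)cc2-c2ccccc2)n2ccnc2)c(Cl)c1` share one core; compound 3 `Clc1ccc(-n2ccc(C(c3ccc(Cl)cc3Cl)n3ccnc3)c2)cc1` stands on a different core, and the difference between the two cores is not broken down here. In an ADME assay on L6 cells (Rattus norvegicus) for cytotoxicity, read by fluorescence and resazurin assay, with a stated time of 72 h (on this read-out lower numbers stand for higher toxicity in this test and higher numbers for lower toxicity in this test), compound 2 gives 14900 nM and compound 1 gives 14300 nM; the step between them is a 1.0-fold lower number from compound 2 to compound 1 (0.02 log units; within the scatter), made by chloro in place of hydrogen on an aromatic carbon. In this assay compound 3 gives 13900 nM, a number within the scatter of the other two, so no order among the three is claimed.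

Compound 4 `Clc1ccc(C(c2ccn(-c3ccc(Cl)cc3Cl)c2)n2ccnc2)c(Cl)c1` is not yet measured in this assay. It differs from compound 3 by chloro in place of hydrogen on an aromatic carbon, the same change as the measured pair, with place lines that agree word for word; the change appears in two pairs in all. The expected step from compound 3 to compound 4 in this assay is a 1.0-fold lower number from compound 3 to compound 4 (0.01 log units; within the scatter), resting on a 1.0-fold lower number from compound 2 to compound 1 (0.02 log units; within the scatter) and on compound 3 at 13900 nM. Compound 4 is therefore estimated at 13500 nM, expected between 7000 nM and 27000 nM.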

Compound 4, half-maximal cytotoxic concentration: 9260 nM
Compound 4: the middle estimate sits 1.5-fold (0.16 log units) above what was measured; the range from low to high includes it.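

Chloro in place of hydrogen on an aromatic carbon, here 4-chlorophenyl to 2,4-dichlorophenyl, gives a 1.5-fold lower number from compound 3 to compound 4 (0.18 log units; within the scatter) in this assay, so on this second core the change again stays inside the usual spread of repeats. Set beside the first pair, the two cores cannot be told apart for this change: the same change on two cores in this assay, a 1.0-fold lower number (0.02 log units; within the scatter) from compound 2 to compound 1 and a 1.5-fold lower number (0.18 log units; within the scatter) from compound 3 to compound 4, 1.4-fold (0.16 log units) apart, within the scatter of two such steps

Over these two pairs the change carries from one core to the other without a step that can be read, but this does not show that chloro lowers the number, and two steps within the scatter give no basis for a rule on further cores.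

The compounds shown leave open whether anything other than chloro on this aromatic carbon, such as a methoxy group, an amine or a carboxylic acid, would move the number beyond the scatter. They also leave open whether a change elsewhere on either core would do so.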